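A few compounds are considered here, and "the series" means these few. Any claim that something is new, unique, unknown or untested is made for them only; others in the source may bear on it.

Measured in a functional assay on HeLa cells (Homo sapiens) for antiproliferative activity, read by MTT assay, with a stated time of 48 h; a lower number here means a stronger inhibitor, a higher number a weaker inhibitor:
- compound 1 `COc1ccc(C(=O)c2ccc(OC)c3c2C=CC(C)(C)O3)c(NC(=O)CBr)c1`: 3680 nM
- compound 2 `COc1ccc(C(=O)c2ccc(OC)c3c2C=CC(C)(C)O3)c(NC(=O)CO)c1`: 310 nM
- compound 3 `COc1ccc(C(=O)c2ccc(OC)c3c2C=CC(C)(C)O3)c(NC(=O)CN)c1`: 100 nM

Compound 3 has the lowest number of the three, and both other compounds lie beyond the scatter from it. The next compound, compound 4 `CNCC(=O)Nc1cc(OC)ccc1C(=O)c1ccc(OC)c2c1C=CC(C)(C)O2`, is changed at the amino group of compound 3: methyl in place of hydrogen on an amine nitrogen.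

Among the compounds with values here, no measured step makes this exact change. The nearest evidence comes from replacing the whole group on the same saturated chain carbon, which gave a modest step, a 3.1-fold lower number from compound 2 to compound 3 (0.49 log units; beyond the scatter), and a large one, a 37-fold lower number from compound 1 to compound 3 (1.57 log units; beyond the scatter). These steps show that the number responds to changes at this site, but they say nothing direct about a methyl on the nitrogen. As the amine nitrogen stays in place, only a small shift is expected, leaning towards a higher number, since compound 3 at 100 nM is the lowest so far. The expected step is a 1.5-fold higher number from compound 3 to compound 4 (0.18 log units; within the scatter). Compound 4 is estimated at 150 nM. The estimated range for compound 4 runs from 55 nM to 420 nM.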

Compound 4, half-maximal inhibitory concentration: 2170 nM
Beside the measured number, compound 4's estimate is 14-fold (1.16 log units) below it; the whole stated range lies below it.
By their numbers in this assay, from the lowest: compound 3; then compound 2; then compounds 4 and 1 (each within the scatter of the next).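

In this assay, the amine nitrogen proves far more sensitive than the replacements of the whole group suggested: a single methyl in place of hydrogen gives a 22-fold higher number from compound 3 to compound 4 (1.34 log units; beyond the scatter). The advantage of the amino group therefore does not extend to methylamino on this saturated chain carbon, since methylamino in place of hydroxy gives a 7.0-fold higher number from compound 2 to compound 4 (0.85 log units; beyond the scatter), and methylamino in place of bromo gives only a 1.7-fold lower number from compound 1 to compound 4 (0.23 log units; within the scatter). Nothing available explains why one methyl on this nitrogen has so large an effect.

On these data alone, what a dimethylamino or ethylamino group, or a longer chain carrying the amino group, would do here remains open. With only one substituted amine among the compounds shown, it is also unclear whether this step is specific to methyl or would follow from any group on this nitrogen.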